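Working notes: the step from compound 3 to compound 4

A few compounds are considered here, and "the series" means these few. Any claim that something is new, unique, unknown or untested is made for them only; others in the source may bear on it.

The series shares one core, seen in compound 1 `O=C(/C=C/c1ccccc1)Nc1ccc2ncnc(Nc3cccc(Br)c3)c2c1`, which in a functional assay on B16-F10 cells (Mus musculus) for inhibition, read by MTT assay, with a stated time of 48 h (on this read-out lower numbers stand for stronger inhibition and higher numbers for weaker inhibition), gives 1.45 ug/mL. Compound 2 `Cc1ccc(/C=C/C(=O)Nc2ccc3ncnc(Nc4cccc(Br)c4)c3c2)cc1` gives 1.39 ug/mL in this assay, and compound 3 `O=C(/C=C/c1ccccc1Br)Nc1ccc2ncnc(Nc3cccc(Cl)c3)c2c1` gives 1.65 ug/mL. On these numbers compound 3 stands highest of the three, but its gap to compound 1 and to compound 2 is within the scatter, so no order among the three can be read from them. Within the data shown here, the single one-point step measured so far, a 1.0-fold lower number from compound 1 to compound 2 (0.02 log units; within the scatter), also falls within the scatter.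

Compound 4 `O=C(/C=C/c1ccc([N+](=O)[O-])cc1)Nc1ccc2ncnc(Nc3cccc(Cl)c3)c2c1` is not yet measured. It differs from compound 3 by 4-nitrophenyl in place of 2-bromophenyl on a double-bonded chain carbon bound to a double-bonded chain carbon. Among the measured compounds shown here, the step from compound 1 to compound 2 is the only measured step that alters the phenyl ring on the double-bonded chain carbon, and it left the number where it was. For the measured compounds named here, no measured step exchanges a bromine for a nitro group on that ring, so that part of the change has no precedent in the data.

Because a 1.0-fold lower number from compound 1 to compound 2 (0.02 log units; within the scatter) stayed within the scatter, the expected step of a 1.0-fold lower number from compound 3 to compound 4 (0.01 log units; within the scatter) is none beyond the scatter. For compound 4 the expected value in this assay is 1.6 ug/mL, with a range from 0.7 ug/mL to 3.6 ug/mL.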

Compound 4, half-maximal inhibitory concentration: 2.05 ug/mL
Compound 4: the middle estimate sits 1.3-fold (0.11 log units) below what was measured; measured number inside the range.
By their numbers in this assay, from the lowest: compounds 2, 1, 3 and 4 (each within the scatter of the next).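

Across the exchange of 2-bromophenyl for 4-nitrophenyl on a double-bonded chain carbon bound to a double-bonded chain carbon, this assay shows a 1.2-fold higher number from compound 3 to compound 4 (0.09 log units; within the scatter). The earlier step at this ring, a 1.0-fold lower number from compound 1 to compound 2 (0.02 log units; within the scatter), only added a methyl, whereas this one replaces the bromine with a nitro group, raises the group from 7 to 9 heavy atoms and from 0 to 2 hydrogen-bond acceptors, and still leaves the number within the scatter, so on these two steps the ring has tolerated both a small and a larger change in this read-out, with no step beyond the scatter yet to mark a preference. No measurement on hand speaks to why the number holds across this exchange.

The single step changes the substituent and its place on the ring together, so the shown compounds cannot separate the nitro group from its placing, nor say how bromine would behave at the position the nitro group occupies. Going by these compounds, whether an amine or a carboxylic acid on this ring, or a longer chain in place of the phenyl, would move the number beyond the scatter remains open.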